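Second Ethyl on the Aryl Ring: What to Expect

The compounds below may be only part of what the source reports. "The series", "measured", "known", "first", "only" and "open" are said of these compounds alone.

Compound 3 `CCc1ccccc1-n1nncc1CN1C(=O)C2(C(C#N)=C(N)Oc3c(N)cc4nc5ccccc5nc4c32)c2ccccc21` was tested in an ADME assay on L02 cells (Homo sapiens) for antiproliferative activity, read by MTT assay, with a stated time of 48 h (a higher number here means a weaker inhibitor, a lower number a stronger inhibitor), where compound 3 gives 22900 nM. Of the two numbers obtained this is the lower, though only within the scatter of compound 1 `N#CC1=C(N)Oc2c(c3nc4ccccc4nc3c3ccccc23)C12C(=O)N(Cc1cnnn1-c1cccc(Cl)c1)c1ccccc12`, which in this assay gives 35200 nM. Compound 2 `Cc1ccc(Cl)cc1-n1nncc1CN1C(=O)C2(C(C#N)=C(N)Oc3c2c2nc4ccccc4nc2c2ccccc32)c2ccccc21` gives only a limit of the assay in this assay, namely > 50000 nM. Compound 4 `CCc1cccc(CC)c1-n1nncc1CN1C(=O)C2(C(C#N)=C(N)Oc3c(N)cc4nc5ccccc5nc4c32)c2ccccc21` carries the change (ethyl in place of hydrogen on an aromatic carbon), read one bond further out as 2-ethylphenyl to 2,6-diethylphenyl. Among the compounds with values here, the one comparable step here is an at least 1.4-fold higher number from compound 1 to compound 2 (0.15 log units; that floor lies within the scatter), whose floor lies within the scatter. Because that step an at least 1.4-fold higher number from compound 1 to compound 2 (0.15 log units; that floor lies within the scatter) was small, compound 4 is expected to show at most a modest rise, estimated as a 1.4-fold higher number from compound 3 to compound 4 (0.15 log units; within the scatter). Compound 4 is therefore expected to give about 32000 nM, between 13000 nM and 80000 nM.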

Compound 4, half-maximal inhibitory concentration: > 50000 nM
Compound 4: no number, only a limit (the forecaster's own chance of this, stated with the estimate: 25%); at least 1.5-fold (0.19 log units) between middle value and limit.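

In this assay, ethyl in place of hydrogen on this aromatic carbon, ortho to a large group, gives an at least 2.1-fold higher number from compound 3 to compound 4 (0.33 log units; beyond the scatter). Unlike the earlier methyl step, whose floor lay within the scatter, this step clears it, so the change makes a readable difference at this place. Compound 4 gives only a limit, so the step is a floor and its full size stays unknown: the limit of > 50000 nM in this assay, at which 2 of the 4 values shown sit.

The compounds shown leave open how an amine or a hydroxyl group at this place would read. They also leave open whether a methyl group here would give a smaller step.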